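Fluoro in Place of Hydrogen on the Carboxyphenyl End

This account rests on a few compounds, and the source may have more. Where it says the series, first, only, none or still open, it means among the compounds named here.

Measured so far:
compound 1, `COC(=O)c1ccc(OCCCCOc2ccc(C(=O)CC(C)C)c(O)c2C)cc1`, gives 22.7%
compound 2, `Cc1c(OCCCCOc2cccc(C(=O)O)c2)ccc(C(=O)CC(C)C)c1O`, gives 69.9%

In an assay on HEK293 cells for positive allosteric modulation of metabotropic glutamate receptor 3 (Rattus norvegicus), read by thallium flux, with a stated time of 2.5 min (a lower number here means a smaller maximal response, a higher number a larger maximal response), compound 2 stands highest of the two numbers; its nearest neighbour is compound 1, and the gap between them is the step of a number 47.2 percentage points higher from compound 1 to compound 2 (beyond the scatter). Compound 3, `Cc1c(OCCCCOc2ccc(F)c(C(=O)O)c2)ccc(C(=O)CC(C)C)c1O`, has not been measured. It differs from compound 2 in one place: fluoro in place of hydrogen on an aromatic carbon. The fluoro enters on an aromatic carbon of the six-membered ring that already carries the carboxy group, ortho to that group.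

Going by the values given here, no measured step bears directly on this change. Among the compounds with values here, the only step available, a number 47.2 percentage points higher from compound 1 to compound 2 (beyond the scatter), exchanges the whole carboxyphenyl for a methoxycarbonylphenyl and so speaks to a different change. With nothing comparable to lean on, compound 3 is expected to stay close to compound 2, with a step of a number 3.9 percentage points lower from compound 2 to compound 3 (within the scatter) that lies within the scatter. The estimate for compound 3 in this assay is 66%, within the range 42% to 90%.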

Compound 3, largest response reached (reported as percent of maximum), in percent of the reference or control that the assay uses: 81.7%
Beside the measured number, compound 3's estimate is 15.7 percentage points below it; the measured number falls inside the stated range.
By their numbers in this assay, from the lowest: compound 1; then compound 2; then compound 3.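

In this assay, going by these compounds alone, this is the first reading of a change at this aromatic carbon, and the added fluoro, ortho to a carboxy group, raises the response rather than leaving it in place: a number 11.8 percentage points higher from compound 2 to compound 3 (beyond the scatter). The step is modest, but it shows that the carboxyphenyl end can still gain from a single added atom. Taken as a whole, the exchange of 4-(methoxycarbonyl)phenyl for 3-carboxy-4-fluorophenyl gives a number 59 percentage points higher from compound 1 to compound 3 (beyond the scatter), and nothing on hand accounts for the rise from the added fluoro.

The compounds shown leave open whether chloro or methyl on this same carbon would give a similar rise. They also leave open whether the fluoro would raise the response if a methyl ester replaced the carboxylic acid.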